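A few compounds are considered here, and "the series" means these few. Any claim that something is new, unique, unknown or untested is made for them only; others in the source may bear on it.

Compound 1 `NS(=O)(=O)N1CCC(C(=O)/C(=N/O)Nc2ccc(F)c(Br)c2)CC1` was tested in an assay for inhibition of Tryptophan 2,3-dioxygenase (Homo sapiens), with a stated time of 1 h (a lower number here means a stronger inhibitor, a higher number a weaker inhibitor), where compound 1 gives 62500 nM. Two close relatives were measured in the same way. Compound 2 `O=C(/C(=N/O)Nc1ccc(F)c(Br)c1)C1CCN(C(=O)NCc2ccccc2)CC1` gives 89800 nM, and compound 3 `NS(=O)(=O)NC[C@H]1CC[C@H](C(=O)/C(=N/O)Nc2ccc(F)c(Br)c2)CC1` gives 58700 nM. Among these three, compound 1 sits in the middle, and all three numbers lie within the scatter of one another, so none can be called stronger or weaker than the rest.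

Compound 4 `O=C(/C(=N/O)Nc1ccc(F)c(Br)c1)C1CCN(S(=O)(=O)NCc2ccccc2)CC1` is the next variation. Compared with compound 1, the change is benzyl in place of hydrogen on a sulfonamide nitrogen. Going by the values given here, the only measured step that touches this part of the molecule is the one from compound 1 to compound 2, which gave a 1.4-fold higher number from compound 1 to compound 2 (0.16 log units; within the scatter); there a benzyl-bearing group took the place of the whole sulfamoyl, and the readout barely moved. A benzyl hung on the sulfonamide nitrogen is therefore expected to leave the number roughly where it is, with at most a small drift upward.

For compound 4 the expected value in this assay is 70000 nM, within a range from 30000 nM to 160000 nM. This corresponds to an estimated step of a 1.1-fold higher number from compound 1 to compound 4 (0.05 log units; within the scatter).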

Compound 4, half-maximal inhibitory concentration: > 100000 nM
Compound 4: no number, only a limit; the forecaster's own chance of this, stated with the estimate: 15%; middle value at least 1.4-fold (0.15 log units) away from the limit.
By their numbers in this assay, from the lowest: compounds 3, 1 and 2 (each within the scatter of the next). At a limit, above all of these: compound 4.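

In this assay compound 4 gives > 100000 nM, which is a limit and not a number. The step reads an at least 1.6-fold higher number from compound 1 to compound 4 (0.20 log units; that floor lies within the scatter), so benzyl in place of hydrogen on a sulfonamide nitrogen gives no sign of a lower number, but its floor does not separate the two compounds. Going by these compounds alone, the earlier compounds all gave readable numbers, whereas this change leaves the size of the step open at its upper end, and only this compound ends at the limit: the limit of > 100000 nM in this assay, at which 1 of the 4 values shown sits.

Still open, going by these compounds, is whether a methyl on the same sulfonamide nitrogen, or a longer chain such as phenylethyl, would give a readable number. Also open, on these data alone, is whether an amine or a carboxylic acid at this place would bring the number clearly below that of compound 1.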